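Ester variation on a glycoside core: cyclohexyl to methoxyphenyl

This account rests on a few compounds, and the source may have more. Where it says the series, first, only, none or still open, it means among the compounds named here.

Within the data shown here, compound 1 `C/C=C1/[C@H](O[C@@H]2O[C@H](CO)[C@@H](O)[C@H](O)[C@H]2O)OC=C(C(=O)OC)[C@H]1CC(=O)OCCC1CCCCC1` is the only member of the set with a numerical reading: in a functional assay on SK-BR-3 cells (Homo sapiens) for antiproliferative activity, read by MTT assay, with a stated time of 72 h (on this read-out higher numbers stand for weaker inhibition and lower numbers for stronger inhibition), compound 1 gives 2000 nM. Compound 2 `C/C=C1/[C@H](O[C@@H]2O[C@H](COC(C)=O)[C@@H](OC(C)=O)[C@H](OC(C)=O)[C@H]2OC(C)=O)OC=C(C(=O)O)[C@H]1CC(=O)O` reaches only a limit in this assay, > 20000 nM. Compound 3 `C/C=C1/[C@H](O[C@@H]2O[C@H](COC(C)=O)[C@@H](OC(C)=O)[C@H](OC(C)=O)[C@H]2OC(C)=O)OC=C(C(=O)O)[C@H]1CC(=O)OCCCCCCCCCCCCCCC` likewise stops at a limit in this assay, > 20000 nM. Two of the three readings sit at the limit of > 20000 nM in this assay, at which 2 of the 3 values shown sit. Among the measured compounds shown here, no step between measured compounds is available, so nothing measured anchors the change to compound 4 `C/C=C1/[C@H](O[C@@H]2O[C@H](CO)[C@@H](O)[C@H](O)[C@H]2O)OC=C(C(=O)OC)[C@H]1CC(=O)OCCc1ccc(OC)cc1`, which differs from compound 1 as 4-methoxyphenyl in place of cyclohexyl on a saturated chain carbon, two bonds along the chain from an oxygen next to a carbonyl group. Both groups are one six-membered ring at the same place on the chain. The step from compound 1 to compound 4 is expected to stay within the scatter, without a clear direction, as a 1.3-fold higher number from compound 1 to compound 4 (0.10 log units; within the scatter). Compound 4 is expected at 2500 nM, within 800 nM to 8000 nM.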

Compound 4, half-maximal inhibitory concentration: > 20000 nM
Compound 4 was reported as a limit (the forecaster's own chance of this, stated with the estimate: 5%); middle value at least 8.0-fold (0.90 log units) away from the limit.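

Among these compounds, this is the first readable step: in this assay, 4-methoxyphenyl in place of cyclohexyl on a saturated chain carbon gives an at least 10-fold higher number from compound 1 to compound 4 (1.00 log units; beyond the scatter). Two six-membered rings at the same place are therefore not interchangeable here. Compound 4 gives > 20000 nM, which is a limit of the assay and not a number, so the full size of the loss stays unknown: the limit of > 20000 nM in this assay, at which 3 of the 4 values shown sit.

Going by these compounds, whether the loss goes with the aromatic ring itself or with its methoxy group stays open. A plain phenyl at this place would separate the two.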